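The source may hold more compounds than are shown below. What is called first, only, known or untested is meant among the compounds shown, and "the series" means these compounds.

Measured so far:
compound 1 `Cc1nc(-c2cccc(F)c2)c(C(=O)N2CCN(c3cccc(Cl)c3)CC2)o1`: 33.7 nM
compound 2 `CCc1nc(-c2cccc(F)c2)c(C(=O)N2CCN(c3cccc(Cl)c3)CC2)o1`: 317 nM
compound 3 `CCc1nc(-c2ccc(OC)c(OC)c2)c(C(=O)N2CCN(c3cccc(Cl)c3)CC2)o1`: "not active" (no number reported)

In a functional assay on HL-60 cells (Homo sapiens) for inhibition, read by MTT assay, with a stated time of 72 h (a lower number here means a stronger inhibitor, a higher number a weaker inhibitor), compound 1 gives 33.7 nM and compound 2 gives 317 nM. The step of a 9.4-fold higher number from compound 1 to compound 2 (0.97 log units; beyond the scatter) goes with methyl in place of hydrogen on a saturated chain carbon bound to an aromatic carbon. Compound 3 carries a different core; the difference between the cores of compound 1 and compound 3 is not broken down here. In this assay compound 3 was reported as "not active" (no number reported), and no number is available for it.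

Compound 4 `CCCc1nc(-c2ccc(OC)c(OC)c2)c(C(=O)N2CCN(c3cccc(Cl)c3)CC2)o1` is not yet measured. It differs from compound 3 by methyl in place of hydrogen on a saturated chain carbon, two bonds along the chain from an aromatic carbon. This is the same kind of change as that from compound 1 to compound 2, not the same: there the carbon is bound to an aromatic carbon, here it is two bonds along the chain from an aromatic carbon.

Compound 3 gave no number, and the step of a 9.4-fold higher number from compound 1 to compound 2 (0.97 log units; beyond the scatter) went toward weaker inhibition, so no recovery is expected. Compound 4 is expected to give about 30000 nM in this assay, most likely reported only as a limit.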

Compound 4, half-maximal inhibitory concentration: "not active" (no number reported)
The entry for compound 4 holds no number; there is nothing to compare the estimate with.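

Compound 3 and compound 4 both stand without a number in this assay, so no step can be read between them. Left open is what the change from ethyl to propyl does where a number exists. No supporting evidence bears on this result.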